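Adding a methyl to compound 2

The compounds below may be only part of what the source reports. "The series", "measured", "known", "first", "only" and "open" are said of these compounds alone.

Measured in an ADME assay on MRC5 cells (Homo sapiens) for cytotoxicity, read by fluorescence, with a stated time of 72 h (on this read-out higher numbers stand for weaker inhibition and lower numbers for stronger inhibition), so far
Compound 1 (`CC1(COc2ccc(-c3ccc(F)cc3)cc2)Cn2cc([N+](=O)[O-])nc2O1`) gives > 64000 nM as a limit
Compound 2 (`O=[N+]([O-])c1cn2c(n1)OC(COc1ccc(-c3ccc(C(F)(F)F)cc3)cn1)C2`) gives 45000 nM as a number
Compound 3 (`O=[N+]([O-])c1cn2c(n1)OC(COc1ccc(-c3ccc(OC(F)(F)F)cc3)cn1)C2`) gives 47000 nM as a number

Compound 2 stands level with compound 3, as the step of a 1.0-fold higher number from compound 2 to compound 3 (0.02 log units; within the scatter) shows. That step is the only measured one, and it concerns trifluoromethoxy in place of trifluoromethyl on an aromatic carbon, so it says little here. For compound 1 the reading is a limit, given as the limit of > 64000 nM in this assay, at which 1 of the 3 values shown sits, and not a number. Compound 4 (`CC1(COc2ccc(-c3ccc(C(F)(F)F)cc3)cn2)Cn2cc([N+](=O)[O-])nc2O1`) differs from compound 2 by methyl in place of hydrogen on a saturated ring carbon with methyl in place of hydrogen on a saturated ring carbon. Compound 1 also carries such a methyl but differs elsewhere, and it reads > 64000 nM as a limit. A small upward move is therefore expected, estimated as a 1.2-fold higher number from compound 2 to compound 4 (0.08 log units; within the scatter) in this assay overall. The estimate for compound 4 is 54000 nM with an expected range of 28000 nM to 95000 nM in this assay when measured.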

Compound 4, half-maximal inhibitory concentration: > 64000 nM
Compound 4: a limit, no number (the forecaster's own chance of this, stated with the estimate: 35%); middle value at least 1.1-fold (0.07 log units) away from the limit.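

In this assay, going by these compounds alone, methyl in place of hydrogen on this saturated ring carbon gives an at least 1.4-fold higher number from compound 2 to compound 4 (0.15 log units; that floor lies within the scatter), the only reading of this change with the rest of compound 2 held fixed. The floor of that step does not separate the two compounds, so the data show no stronger inhibition with the methyl but cannot show a real weakening. The reading of compound 4 is a limit and not a number, and a second compound now shares that limit: the limit of > 64000 nM in this assay, at which 2 of the 4 values shown sit.

As far as these compounds go, the true size of the step stays open. So does whether an ethyl or a hydroxymethyl on the same carbon would read alike.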